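This account rests on a few compounds, and the source may have more. Where it says the series, first, only, none or still open, it means among the compounds named here.

In an ADME assay on MT4 cells (Homo sapiens) for cytotoxicity, read by XTT assay, with a stated time of 3 days (a higher number here means that more compound is tolerated, a lower number that less compound is tolerated), compound 2 (`CCOCn1c(Cc2ccccc2)c(Br)c(=O)[nH]c1=O`) gives 155000 nM and compound 1 (`O=c1[nH]c(=O)n(COCc2ccccc2)c(Cc2cc(F)cc(F)c2)c1I`) gives 121000 nM, two values within the scatter of each other. Compound 3 (`O=c1[nH]c(=O)n(COCc2ccccc2)c(Cc2ccccc2)c1Br`) gives 67400 nM, and compound 2 stands clearly higher than that.

The compound still to be measured is compound 4 (`CCOCn1c(Cc2ccccc2)c(N(C)C)c(=O)[nH]c1=O`), which differs from compound 2 in a single group: dimethylamino in place of bromo on an aromatic carbon. In words, dimethylamino takes the place of bromo on an aromatic carbon of the ring.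

For the measured compounds named here, only one measured step starts from compound 2, and it does not touch that carbon. It is a 2.3-fold lower number from compound 2 to compound 3 (0.36 log units; beyond the scatter), a modest change that puts phenyl in place of methyl on a saturated chain carbon. Going by the values given here, no compound here shows what a change at the bromo carbon does, so this step serves only as a rough guide to size. With so little to go on, no step beyond the scatter is expected in this assay, and the direction stays uncertain.

The estimate means a 1.3-fold lower number from compound 2 to compound 4 (0.11 log units; within the scatter), a small expected change. For compound 4 the expected value is 120000 nM, with an estimated range from 50000 nM to 280000 nM.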

Compound 4, half-maximal cytotoxic concentration: 166000 nM
Compound 4: the middle estimate sits 1.4-fold (0.14 log units) below what was measured, and the stated range covers the measured number.
By their numbers in this assay, from the lowest: compounds 3, 1, 2 and 4 (each within the scatter of the next, the first and the last beyond it).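

In this assay, for the compounds shown here, the earlier compounds showed nothing about the aromatic carbon that carries bromo in compound 2, and the new pair now gives a first reading there: a 1.1-fold higher number from compound 2 to compound 4 (0.03 log units; within the scatter). Going by these compounds alone, replacing bromo, a single heavy atom, with dimethylamino, which has three heavy atoms and one hydrogen-bond acceptor, therefore leaves the two compounds indistinguishable in this cell test, whereas the only earlier step beyond the scatter, a 2.3-fold lower number from compound 2 to compound 3 (0.36 log units; beyond the scatter), lies on a saturated chain carbon rather than at this ring position. No measured evidence bears on why this swap leaves the number within the scatter.

On these data alone, this is a single pair with an ethoxymethyl group, so it remains open whether dimethylamino would behave the same way on the phenyl-bearing chain of compound 3. As far as these compounds go, it is also open whether a different group on this carbon, such as a carboxylic acid, a methoxy group or a longer chain, would stay within the scatter or shift the number clearly.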